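The compounds below may be only part of what the source reports. "The series", "measured", "known", "first", "only" and "open" are said of these compounds alone.

Measured in a functional assay on HepG2 cells (Homo sapiens) for cytotoxicity, read by MTT assay; a higher number here means a weaker inhibitor, a lower number a stronger inhibitor:
Compound 1 `CC1(C)CCc2c(C3CCc4ccc(O)cc4O3)ccc(O)c2O1`: > 100000 nM, a limit.
Compound 2 `CC1(C)CCc2c([C@@H]3CCc4ccc(O)cc4O3)ccc(O)c2O1`: > 100000 nM, a limit.

Compound 2 has no numerical value in this assay and stands at the limit of > 100000 nM in this assay, at which 2 of the 2 values shown sit. For the measured compounds named here, the only measured step, a step that the two limits leave unreadable from compound 1 to compound 2, concerns (the fact that one of compounds 1 and 2 is drawn with a defined configuration and the other without, at the place where they differ), and it gives no size to carry forward. Compound 3 `CC1(C)CCc2c([C@H]3CCc4ccc(O)cc4O3)ccc(O)c2O1` changes only the drawn configuration: the two compounds have the same atoms and bonds and differ only in configuration as drawn: 1 of 1 stereo elements differ; a stereocentre at a saturated ring carbon is drawn S in compound 2 and R in compound 3. Since compound 2 gives > 100000 nM, which is a limit, no step beyond the scatter is expected in this assay, and no direction can be named. The expected change is a step that the limit leaves unreadable from compound 2 to compound 3, an estimate that carries little weight. For compound 3 the estimated value is 120000 nM, with an expected range from 50000 nM to 300000 nM.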

Compound 3, half-maximal inhibitory concentration: > 100000 nM
Compound 3 ended at the assay's limit; the forecaster's own chance of this, stated with the estimate: 90%; the middle value is on the limit's open side.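

In this assay compound 3 gives > 100000 nM as a limit. For the compounds shown here, no step among compound 1, compound 2 and compound 3 can be read, and one fact settles this: (the limit of > 100000 nM in this assay, at which 3 of the 3 values shown sit). The compounds shown leave open whether the drawn configuration at the stereocentre affects cytotoxicity at all.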